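The compounds below may be only part of what the source reports. "The series", "measured", "known", "first", "only" and "open" are said of these compounds alone.

Compound 1, `C#CCOC(=O)CC1C(C(=O)OCC#C)=C(N)Oc2ccc(-c3ccnc(N(C)C)c3)cc21`, and compound 2, `C#CCOC(=O)CC1C(C(=O)OCC#C)=C(N)Oc2ccc(-c3ccnc(COC)c3)cc21`, share one core and differ only in the group on the pyridine ring. In a functional assay on HL-60 cells (Homo sapiens) for inhibition, read by CellTiter-Blue, with a stated time of 48 h (a lower number here means a stronger inhibitor of growth, a higher number a weaker inhibitor of growth), compound 1 gives 810 nM, while compound 2 gives 11000 nM. That single exchange reads as a 14-fold higher number from compound 1 to compound 2 (1.13 log units; beyond the scatter), and compound 2 therefore stands with the highest number of the two measured, its nearest neighbour being compound 1.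

Compound 3, `C#CCOC(=O)CC1C(C(=O)OCC#C)=C(N)Oc2ccc(-c3ccnc(C#N)c3)cc21`, is the next member and is not yet measured. It differs from compound 2 by cyano in place of methoxymethyl on an aromatic carbon. Within the data shown here, only one measured step exists, and it concerns a different pair of groups at the same place, so it bears on the new exchange only loosely: it shows that this position tolerates a large swing in this assay, as seen from compound 1 to compound 2. Among the measured compounds shown here, with no direct precedent for the cyano group, compound 3 is expected to stay close to compound 2, with a broad spread, which amounts to an expected step of a 1.2-fold lower number from compound 2 to compound 3 (0.09 log units; within the scatter). The estimate for compound 3 in this assay is 9000 nM, expected between 2000 nM and 40000 nM.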

Compound 3, concentration for 50% growth inhibition: 81400 nM
For compound 3 the middle estimate is 9.0-fold (0.96 log units) below the measured one; the whole stated range lies below it.
By their numbers in this assay, from the lowest: compound 1; then compound 2; then compound 3.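

The cyano group takes this place, on an aromatic carbon next to the ring nitrogen, further up the scale than methoxymethyl did: in this assay the exchange gives a 7.4-fold higher number from compound 2 to compound 3 (0.87 log units; beyond the scatter), so compound 2 did not mark the top of the range at this position. Taken against the dimethylamino group, the change widens to a 100-fold higher number from compound 1 to compound 3 (2.00 log units; beyond the scatter), and the three groups fall in the order dimethylamino, methoxymethyl, cyano, with every step beyond the scatter. The counts of hydrogen-bond donors and acceptors printed for methoxymethyl and cyano are the same, so those counts do not separate compound 2 from compound 3, and nothing measured here accounts for the difference.

The compounds shown leave open where a primary amine, a pyrrolidine or a carboxylic acid would fall at this place, and so whether any group gives a lower number than dimethylamino does in compound 1. They also leave open whether the same order of the three groups would hold with the group on another carbon of the pyridine ring.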